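Methyl on the Shared Core and Cytotoxicity

This account rests on a few compounds, and the source may have more. Where it says the series, first, only, none or still open, it means among the compounds named here.

Measured so far:
compound 1 `CC(C)N(C)c1nc(Cc2c(F)cccc2F)cc(=O)[nH]1`: 85000 nM
compound 2 `O=c1cc(Cc2c(F)cccc2F)nc(N2CCC3(CC2)OCCO3)[nH]1`: > 69000 nM
compound 3 `Cc1c(Cc2c(F)cccc2F)nc(N(C)C(C)C)[nH]c1=O`: 79000 nM

In an ADME assay on MT4 cells (Homo sapiens) for cytotoxicity, read by MTT assay, with a stated time of 4 days (on this read-out lower numbers stand for higher toxicity in this test and higher numbers for lower toxicity in this test), compound 1 gives 85000 nM. Compound 3 `Cc1c(Cc2c(F)cccc2F)nc(N(C)C(C)C)[nH]c1=O` differs from it by methyl in place of hydrogen on an aromatic carbon, and in this assay compound 3 gives 79000 nM; the step of a 1.1-fold lower number from compound 1 to compound 3 (0.03 log units; within the scatter) is one the data call within the scatter. For compound 2 `O=c1cc(Cc2c(F)cccc2F)nc(N2CCC3(CC2)OCCO3)[nH]1` the read-out is a limit, not a number, and in this assay compound 2 gives > 69000 nM. How the core of compound 2 differs from the core of compound 1 is not broken down here.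

Compound 4 `Cc1c(Cc2c(F)cccc2F)nc(N2CCC3(CC2)OCCO3)[nH]c1=O` has not been measured. It differs from compound 2 by methyl in place of hydrogen on an aromatic carbon, the same kind of change as from compound 1 to compound 3, though here the place is para to a large group and ortho to a 2,6-difluorobenzyl group rather than para to an isopropyl(methyl)amino group. Because the step of a 1.1-fold lower number from compound 1 to compound 3 (0.03 log units; within the scatter) stayed within the scatter, the step from compound 2 to compound 4 in this assay is expected to be small as well, a step that the limit leaves unreadable from compound 2 to compound 4. Compound 4 is therefore estimated to give about 80000 nM in this assay, between 40000 nM and 200000 nM, with a real chance that only a limit is reported, as the limit of > 69000 nM in this assay, at which 1 of the 3 values shown sits, shows.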

Compound 4, half-maximal cytotoxic concentration: > 66000 nM
Compound 4 gave a limit, no number; the forecaster's own chance of this, stated with the estimate: 55%; the middle value does not contradict the limit.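

In this assay compound 2 and compound 4 are each reported only as a limit, not a number, so no step can be read between them. The compounds shown leave open whether methyl in place of hydrogen on an aromatic carbon changes the read-out from compound 2 to compound 4 at all, and by how much.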